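From Fluoro to Chloro on One Aromatic Carbon

This account rests on a few compounds, and the source may have more. Where it says the series, first, only, none or still open, it means among the compounds named here.

In a functional assay on A549 cells (Homo sapiens) for antiproliferative activity, read by MTT assay, with a stated time of 48 h (on this read-out lower numbers stand for stronger inhibition and higher numbers for weaker inhibition), compound 1 `COc1ccc(C(=O)/C=C/c2cc(Br)cc(Br)c2Oc2c([N+](=O)[O-])cc(C(F)(F)F)cc2[N+](=O)[O-])cc1` gives 13.2 ug/mL, while compound 2 `O=C(/C=C/c1cc(Br)cc(Br)c1Oc1c([N+](=O)[O-])cc(C(F)(F)F)cc1[N+](=O)[O-])c1ccc(F)cc1` gives 120 ug/mL. Compound 2 therefore holds the higher of the two numbers and shows the weaker inhibition. Compound 3 `O=C(/C=C/c1cc(Br)cc(Br)c1Oc1c([N+](=O)[O-])cc(C(F)(F)F)cc1[N+](=O)[O-])c1ccc(Cl)cc1` is still unmeasured. Its structure departs from compound 2 in a single change: chloro in place of fluoro on an aromatic carbon. For the measured compounds named here, only one measured step bears on this carbon, where fluoro took the place of methoxy, giving a 9.1-fold higher number from compound 1 to compound 2 (0.96 log units; beyond the scatter). Going by the values given here, that step shows that a swap at this carbon can move the number, but it involves a different pair of groups, and no measured compound yet carries chloro. A smaller step is therefore expected here, leaning towards a lower number and possibly staying within the scatter. The expected change is a 1.6-fold lower number from compound 2 to compound 3 (0.20 log units; within the scatter). For compound 3 the estimated value is 75 ug/mL, with an expected range of 20 ug/mL to 200 ug/mL.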

Compound 3, half-maximal inhibitory concentration: 19.4 ug/mL
Estimate against measurement, compound 3: 3.9-fold (0.59 log units) above, outside the stated range (below it).
By their numbers in this assay, from the lowest: compounds 1 and 3 (each within the scatter of the next); then compound 2.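

In this assay, the exchange of fluoro for chloro on this aromatic carbon gives a 6.2-fold lower number from compound 2 to compound 3 (0.79 log units; beyond the scatter), so replacing a single halogen atom here is enough to change the result. Chloro and methoxy, two very different groups, cannot be told apart at this carbon, with a 1.5-fold higher number from compound 1 to compound 3 (0.17 log units; within the scatter), which leaves compound 2, the fluoro compound, as the one with the weakest inhibition of the three. No measurement is available that would explain this behaviour.

With only three groups shown at this carbon, it remains open whether a hydrogen, a bromo, a methyl or an amine would give a number like that of the fluoro compound or like those of the other two. On these data alone, it is also open whether the same order of groups would hold at any other carbon of the ring or on a different core.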